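Ring-fluorine shift on an amide in a pyrazolopyridine series

The source may report more compounds than this note shows. Statements on the series, on what has been measured and on what is new or still open speak of the compounds shown alone.

Measured compounds:
compound 1 `CCCCn1cc(Cn2nc(N)c3c(C(F)(F)F)cc(-c4ccccc4)nc32)nn1` — a functional assay on HL-60 cells (Homo sapiens) for cytotoxicity, read by MTT assay, with a stated time of 24 h; on this read-out lower numbers stand for stronger inhibition and higher numbers for weaker inhibition: 36.7 ug/mL
compound 2 `Nc1nn(Cc2cn(-c3ccc(F)c(Cl)c3)nn2)c2nc(-c3ccccc3)cc(C(F)(F)F)c12` — this assay: 35 ug/mL
compound 3 `Nc1nn(Cc2cn(CC(=O)Nc3cccc(F)c3)nn2)c2nc(-c3ccccc3)cc(C(F)(F)F)c12` — this assay: 63.9 ug/mL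

Compound 3 is not set apart from the others: the step of a 1.7-fold higher number from compound 1 to compound 3 (0.24 log units; within the scatter) and the step of a 1.8-fold higher number from compound 2 to compound 3 (0.26 log units; within the scatter) both lie within the scatter, as does a 1.0-fold lower number from compound 1 to compound 2 (0.02 log units; within the scatter). Compound 4 `Nc1nn(Cc2cn(CC(=O)Nc3c(F)cccc3F)nn2)c2nc(-c3ccccc3)cc(C(F)(F)F)c12` differs from compound 3 by 2,6-difluorophenyl in place of 3-fluorophenyl on an amide-type nitrogen. Among the measured compounds shown here, no measured step touches the carbamoyl aryl group, so no direct precedent exists; the three steps that are known all stay within the scatter, and compound 4 is therefore expected to show no step beyond the scatter, a 1.1-fold lower number from compound 3 to compound 4 (0.03 log units; within the scatter). Compound 4 is estimated at 60 ug/mL, within 30 ug/mL to 120 ug/mL.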

Compound 4, half-maximal inhibitory concentration: 32.8 ug/mL
Beside the measured number, compound 4's estimate is 1.8-fold (0.26 log units) above it, and the stated range covers the measured number.
By their numbers in this assay, from the lowest: compounds 4, 2, 1 and 3 (each within the scatter of the next).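

In this assay, among the compounds shown here, the change to 2,6-difluorophenyl on the amide-type nitrogen gives the first measured step at this aryl group, a 1.9-fold lower number from compound 3 to compound 4 (0.29 log units; within the scatter), and it stays within the scatter. The ((2,6-difluorophenyl)carbamoyl)methyl group also stands apart from neither group it replaces on the aromatic nitrogen, with a 1.1-fold lower number from compound 2 to compound 4 (0.03 log units; within the scatter) and a 1.1-fold lower number from compound 1 to compound 4 (0.05 log units; within the scatter). No measured evidence bears on why these numbers lie so close. Going by these compounds, whether an amine or a carboxylic acid on this phenyl ring would move the number in this assay beyond the scatter remains open.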